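From compound 3 to compound 4: one phenyl group exchanged

The source may hold more compounds than are shown below. What is called first, only, known or untested is meant among the compounds shown, and "the series" means these compounds.

In a functional assay on A549 cells (Homo sapiens) for cytotoxicity (a higher number here means that more compound is needed for the effect, a lower number that less compound is needed), compound 1 `COC1=C(C)C(=O)/C(=C(O)/C=C/c2ccc(Br)cc2)C(=O)C1(C)C` gives 1.4 ug/mL, compound 2 `COC1=C(C)C(=O)/C(=C(O)/C=C/c2ccc(OC)cc2)C(=O)C1(C)C` gives 3 ug/mL and compound 3 `COC1=C(C)C(=O)/C(=C(O)/C=C/c2ccccc2OC)C(=O)C1(C)C` gives 2.4 ug/mL. Compound 3 thus lies within the scatter of both others, as the steps show: a 1.7-fold higher number from compound 1 to compound 3 (0.23 log units; within the scatter) and a 1.3-fold lower number from compound 2 to compound 3 (0.10 log units; within the scatter). Compound 4 `COC1=C(C)C(=O)/C(=C(O)/C=C/c2ccc(O)cc2)C(=O)C1(C)C` carries 4-hydroxyphenyl in place of 2-methoxyphenyl on a double-bonded chain carbon bound to a double-bonded chain carbon. Among the measured compounds shown here, no measured step tests the hydroxy group directly. For the measured compounds named here, the exchange of 4-methoxyphenyl and 2-methoxyphenyl stayed small, and the only step beyond the scatter is modest: a 2.1-fold higher number from compound 1 to compound 2 (0.33 log units; beyond the scatter). The expected change is therefore none beyond the scatter, with an estimated 1.0-fold higher number from compound 3 to compound 4 (0.02 log units; within the scatter). For compound 4 the estimated value is 2.5 ug/mL, with an expected range of 1.1 ug/mL to 5.5 ug/mL.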

Compound 4, concentration for half-maximal effect: 3.1 ug/mL
Beside the measured number, compound 4's estimate is 1.2-fold (0.09 log units) below it, within the range that was stated.
By their numbers in this assay, from the lowest: compounds 1, 3, 2 and 4 (each within the scatter of the next, the first and the last beyond it).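

Exchanging 2-methoxyphenyl for 4-hydroxyphenyl, which adds a hydrogen-bond donor, stays within the scatter in this assay (a 1.3-fold higher number from compound 3 to compound 4 (0.11 log units; within the scatter)), as does hydrogen in place of methyl on the oxygen (a 1.0-fold higher number from compound 2 to compound 4 (0.01 log units; within the scatter)). Only hydroxy in place of bromo goes beyond it, and modestly (a 2.2-fold higher number from compound 1 to compound 4 (0.35 log units; beyond the scatter)), although compound 3 remains within the scatter of compound 1. No available evidence bears on this result.

As far as these compounds go, whether 4-aminophenyl or 4-carboxyphenyl in this place would shift the number remains open. So does whether a hydroxy group on the 2-carbon of the phenyl would behave like 4-hydroxyphenyl.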